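Fluoro to Methoxy: Expecting Little Change in Cell Toxicity

The source may hold more compounds than are shown below. What is called first, only, known or untested is meant among the compounds shown, and "the series" means these compounds.

Three compounds share one core and differ only in a single group on an aromatic carbon: compound 1 `CC(=O)c1ccc(/N=C2\C=C(OCc3cn(S(=O)(=O)c4ccc(C)cc4)nn3)C(=O)c3ccccc32)cc1`, compound 2 `Cc1ccc(/N=C2\C=C(OCc3cn(S(=O)(=O)c4ccc(C)cc4)nn3)C(=O)c3ccccc32)cc1` and compound 3 `Cc1ccc(S(=O)(=O)n2cc(COC3=C/C(=N\c4ccc(F)cc4)c4ccccc4C3=O)nn2)cc1`. In a functional assay on HCT-116 cells (Homo sapiens) for cytotoxicity, read by MTT assay, with a stated time of 72 h (on this read-out lower numbers stand for stronger inhibition and higher numbers for weaker inhibition), compound 1 gives 6270 nM, compound 2 gives 3610 nM and compound 3 gives 5750 nM. Compound 3 cannot be told apart from the other two, as the data show a 1.1-fold lower number from compound 1 to compound 3 (0.04 log units; within the scatter) and a 1.6-fold higher number from compound 2 to compound 3 (0.20 log units; within the scatter).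

Compound 4 `COc1ccc(/N=C2\C=C(OCc3cn(S(=O)(=O)c4ccc(C)cc4)nn3)C(=O)c3ccccc32)cc1` changes that same group: methoxy in place of fluoro on an aromatic carbon. Put simply, it carries methoxy in place of fluoro on an aromatic carbon, para to a large group. No methoxy value exists yet, so the best guide is the swaps already measured at this place, including a 1.7-fold lower number from compound 1 to compound 2 (0.24 log units; within the scatter). All three stay within the scatter, so no clear shift is expected in this assay in either direction. The expected step is a 1.3-fold lower number from compound 3 to compound 4 (0.11 log units; within the scatter). For compound 4 the estimated value is 4500 nM, with an expected range of 2200 nM to 9000 nM.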

Compound 4, half-maximal inhibitory concentration: 7430 nM
For compound 4 the middle estimate is 1.7-fold (0.22 log units) below the measured one; the range from low to high includes it.
By their numbers in this assay, from the lowest: compounds 2, 3, 1 and 4 (each within the scatter of the next, the first and the last beyond it).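

In this assay, methoxy at this position cannot be told apart from fluoro, with a 1.3-fold higher number from compound 3 to compound 4 (0.11 log units; within the scatter), or from acetyl, with a 1.2-fold higher number from compound 1 to compound 4 (0.07 log units; within the scatter). Methyl and methoxy are the first groups here that can be told apart, if only modestly, with a 2.1-fold higher number from compound 2 to compound 4 (0.31 log units; beyond the scatter) as the only step among these four compounds that passes the scatter. So the position is not entirely indifferent to what it carries, although compound 1 and compound 3 cannot be separated from either compound 2 or compound 4, and all the differences seen so far are small.

The compounds shown leave open whether an amine or a carboxylic acid on this aromatic carbon would move the number further. Nothing available here explains the gap between the methyl and methoxy compounds.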